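A few compounds are considered here, and "the series" means these few. Any claim that something is new, unique, unknown or untested is made for them only; others in the source may bear on it.

Compound 1, `COc1ccc(/C=C/S(=O)(=O)Cc2ccc(OC)cc2)cc1`: in a functional assay on DU-145 cells (Homo sapiens) for antiproliferative activity, read by trypan blue exclusion (on this read-out higher numbers stand for weaker inhibition and lower numbers for stronger inhibition), compound 1 reaches only a limit of the assay, > 20000 nM.
Compound 2, `COc1cc(OC)c(/C=C/S(=O)(=O)Cc2ccc(OC)c(OC)c2OC)c(OC)c1`: in this assay compound 2 gives 12500 nM.
Compound 3, `COc1cc(OC)c(/C=C/S(=O)(=O)Cc2ccc(Cl)cc2)c(OC)c1`: in this assay compound 3 gives 7500 nM.

Compound 3 holds the lower of the two numbers that were obtained, but its nearest neighbour, compound 2, sits within the usual scatter of repeated measurements, so no order can be drawn between them. The value of compound 1 is a limit and not a number (the limit of > 20000 nM in this assay, at which 1 of the 3 values shown sits), and it stands apart from both.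

Compound 4, `COc1cc(OC)c(/C=C/S(=O)(=O)Cc2ccc(C(=O)O)cc2)c(OC)c1`, has not yet been measured. It differs from compound 3 in one place: carboxy in place of chloro on an aromatic carbon of a six-membered aromatic ring of carbon only, para to a large group. Within the data shown here, no pair among the measured compounds shows this same exchange, so the size of the step cannot be read from them. The account expects a moderate rise in the number in this assay, a step that would lie somewhat beyond the scatter. Compound 4 is therefore estimated at about 15000 nM, between 5000 nM and 40000 nM. That estimate amounts to an expected step of a 2.0-fold higher number from compound 3 to compound 4 (0.30 log units; within the scatter).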

Compound 4, half-maximal inhibitory concentration: 10000 nM
Beside the measured number, compound 4's estimate is 1.5-fold (0.18 log units) above it; the range from low to high includes it.
By their numbers in this assay, from the lowest: compounds 3, 4 and 2 (each within the scatter of the next). At a limit, above all of these: compound 1.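

Carboxy in place of chloro on an aromatic carbon, para to a large group, gives a 1.3-fold higher number from compound 3 to compound 4 (0.12 log units; within the scatter), so in this assay the two compounds cannot be told apart. This is the first exchange in a single place among the compounds shown, and it reveals that this position can carry either chloro, with 1 heavy atom and no hydrogen-bond donor, or carboxy, with 3 heavy atoms and 1 hydrogen-bond donor, without a step that lies beyond the scatter. Nothing given here accounts for this outcome.

On these data alone, whether another group at this same place, such as an amine, a methyl ester or an amide, would give a step beyond the scatter remains open, and a single pair can support no trend across groups. As far as these compounds go, it is equally open whether the same exchange would give a similar step on the core of compound 1 or of compound 2, where the other ring carries a different set of methoxy groups.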